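The source may hold more compounds than are shown below. What is called first, only, known or untested is meant among the compounds shown, and "the series" means these compounds.

Measured so far:
compound 1 `O=[N+]([O-])c1cccc(/N=N/N2CCCC2)c1` — 80000 nM
compound 2 `Cc1c(/N=N/c2cccc(C(F)(F)F)c2)ccc(NC[C@@H]2CCCN3CCCC[C@H]23)c1C` — 80000 nM

In an ADME assay on Vero cells (Chlorocebus sabaeus) for cytotoxicity, read by crystal violet staining (on this read-out lower numbers stand for higher toxicity in this test and higher numbers for lower toxicity in this test), compound 1 gives 80000 nM and compound 2 gives 80000 nM; the two values are level at the digits shown, within the scatter, so compound 1 stands alongside compound 2 on this read-out. Compound 3 `FC(F)(F)c1cccc(/N=N/N2CCCC2)c1` has not yet been measured. It differs from compound 1 in one place: trifluoromethyl in place of nitro on an aromatic carbon. Among the compounds with values here, no step between measured compounds covers this change, and the two measured values sit together, so compound 3 is expected to show no step beyond the scatter, no change at the digits printed from compound 1 to compound 3 (within the scatter). Compound 3 is estimated at 80000 nM, within 40000 nM to 160000 nM.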

Compound 3, half-maximal cytotoxic concentration: > 100000 nM
Compound 3 gave a limit, no number; the forecaster's own chance of this, stated with the estimate: 30%; at least 1.2-fold (0.09 log units) between middle value and limit.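

In this assay compound 3 gives > 100000 nM, which is a limit of the assay and not a number. Putting trifluoromethyl in place of nitro on this aromatic carbon gives an at least 1.2-fold higher number from compound 1 to compound 3 (0.09 log units; that floor lies within the scatter), so this change shows no sign of a lower number on this read-out. The full size of the step cannot be read: the limit of > 100000 nM in this assay, at which 1 of the 3 values shown sits.

The compounds shown leave open how a nitrile, an amine or a carboxylic acid on this aromatic carbon would read. They also leave open whether trifluoromethyl would read the same on another carbon of the ring.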